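Adding a Methoxy Group Across Two Related Cores

This account rests on a few compounds, and the source may have more. Where it says the series, first, only, none or still open, it means among the compounds named here.

In a functional assay on HepG2 cells (Homo sapiens) for cytotoxicity, read by MTT assay, with a stated time of 48 h (on this read-out higher numbers stand for weaker inhibition and lower numbers for stronger inhibition), compound 1 `CC(C)=CCC/C(C)=C/CC/C(C)=C/CC[C@@H]1[C@@]2(C)CC/C(=N\OCc3cn(-c4ccccc4)nn3)C(C)(C)[C@@H]2CC[C@@]1(C)O` gives 9520 nM. Compound 2 `COc1cccc(-n2cc(CO/N=C3\CC[C@]4(C)[C@@H](CC/C=C(\C)CC/C=C(\C)CCC=C(C)C)[C@](C)(O)CC[C@H]4C3(C)C)nn2)c1` carries a single change, (methoxy in place of hydrogen on an aromatic carbon), and in this assay compound 2 gives 51300 nM. The step of a 5.4-fold higher number from compound 1 to compound 2 (0.73 log units; beyond the scatter) therefore points toward weaker inhibition. Compound 3 `CC(C)=CCC/C(C)=C/CC/C(C)=C/CC[C@@H]1[C@@]2(C)C/C(=C\c3ccc(OCc4cn(-c5ccccc5)nn4)cc3)C(=O)C(C)(C)[C@@H]2CC[C@@]1(C)O` is built on a different core; the difference between the two cores is not broken down here. In this assay compound 3 gives 126000 nM, the highest of the three numbers. Compound 4 `COc1cccc(-n2cc(COc3ccc(/C=C4\C[C@]5(C)[C@@H](CC/C=C(\C)CC/C=C(\C)CCC=C(C)C)[C@](C)(O)CC[C@H]5C(C)(C)C4=O)cc3)nn2)c1` has not yet been measured. Going by the values given here, it differs from compound 3 by methoxy in place of hydrogen on an aromatic carbon, the same change as the one from compound 1 to compound 2, at a place described in the same words. Among the compounds with values here, because a 5.4-fold higher number from compound 1 to compound 2 (0.73 log units; beyond the scatter) raised the number on the first core, a step in the same direction is expected for compound 4, although the core of compound 3 could respond differently and only one earlier example exists. Compound 4 is therefore expected to give 300000 nM, with a plausible range from 140000 nM to 800000 nM. The expected step is a 2.4-fold higher number from compound 3 to compound 4 (0.38 log units; beyond the scatter). With numbers this high, this assay may report only a limit.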

Compound 4, half-maximal inhibitory concentration: 50100 nM
The estimate for compound 4 lay 6.0-fold (0.78 log units) above the measured number, and the stated range ends above it.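

Swapping phenyl for 3-methoxyphenyl on the second core brings a 2.5-fold lower number from compound 3 to compound 4 (0.40 log units; beyond the scatter) in this assay, a move toward stronger inhibition. Set beside the earlier step, this shows that the same change does not carry over from one core to the other, even in its direction: the same change on two cores in this assay, a 5.4-fold higher number (0.73 log units; beyond the scatter) from compound 1 to compound 2 and a 2.5-fold lower number (0.40 log units; beyond the scatter) from compound 3 to compound 4, 14-fold (1.13 log units) apart, beyond the scatter of two such steps. Going by these compounds alone, the comparison does not show why the two cores respond differently, and with only one pair on each core it gives no general rule for this series.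

The compounds shown leave open whether a hydroxyl group, a fluorine atom or an amine in place of the methoxy would also pull the two cores in opposite directions. They also leave open whether a longer chain, such as ethoxy, would follow the methoxy on each core.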